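This account rests on a few compounds, and the source may have more. Where it says the series, first, only, none or still open, it means among the compounds named here.

Of the compounds shown here, three built on one shared core have been measured in a functional assay on CHO-K1 cells with Glucose-dependent insulinotropic receptor (Homo sapiens) as the target, read by a luciferase reporter, with a stated time of 5 h; on this read-out higher numbers stand for larger maximal responses and lower numbers for smaller maximal responses. Compound 1 `CCCOC(=O)N1CCC(Oc2ncnc3c2CCN3c2ccc(S(C)(=O)=O)cc2F)CC1` gives 111% in this assay. Compound 2 `CCCCOC(=O)N1CCC(Oc2ncnc3c2CCN3c2ccc(S(C)(=O)=O)cc2F)CC1` gives 131%, and compound 3 `CSC(=O)N1CCC(Oc2ncnc3c2CCN3c2ccc(S(C)(=O)=O)cc2F)CC1` gives 135%. Lengthening the chain by methyl in place of hydrogen on a saturated chain carbon, three bonds along the chain from an oxygen next to a carbonyl group brought a number 20 percentage points higher from compound 1 to compound 2 (beyond the scatter). Exchanging the group on the carbonyl carbon gave a number 24 percentage points higher from compound 1 to compound 3 (beyond the scatter), while compound 2 and compound 3 sit close together, as a number 4 percentage points higher from compound 2 to compound 3 (within the scatter) shows.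

Compound 4 `CCSC(=O)N1CCC(Oc2ncnc3c2CCN3c2ccc(S(C)(=O)=O)cc2F)CC1` is not yet measured. It differs from compound 3 by methyl in place of hydrogen on a saturated chain carbon bound to a sulfur. Going by the values given here, this is the same kind of change as the one from compound 1 to compound 2, though the place differs: there the methyl entered on a saturated chain carbon three bonds along the chain from an oxygen next to a carbonyl group, here on a saturated chain carbon bound to a sulfur. The two cores themselves differ by methylsulfanyl in place of propoxy on a carbonyl carbon.

A step of a number 5 percentage points higher from compound 3 to compound 4 (within the scatter) is expected from compound 3 to compound 4, smaller than the earlier one, because compound 3 already reaches 135% and the earlier lengthening gave only a number 20 percentage points higher from compound 1 to compound 2 (beyond the scatter). Compound 4 is therefore expected to give about 140%, most likely between 120% and 160%.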

Compound 4, largest response reached (reported as percent of maximum), in percent of the reference or control that the assay uses: 128%
For compound 4 the middle estimate is 12 percentage points above the measured one; the measured number falls inside the stated range.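

In this assay the added methyl does not carry over unchanged from one core to the other: the same change on two cores in this assay, a number 20 percentage points higher (beyond the scatter) from compound 1 to compound 2 and a number 7 percentage points lower (within the scatter) from compound 3 to compound 4, 27 percentage points apart, beyond the scatter of two such steps The new step, a number 7 percentage points lower from compound 3 to compound 4 (within the scatter), shows no gain on the sulfur-linked core, so the rise seen on the oxygen-linked core cannot be assumed for this kind of change. Going by these compounds alone, with the ethylsulfanyl group in place, the picture is a number 17 percentage points higher from compound 1 to compound 4 (beyond the scatter) and a number 3 percentage points lower from compound 2 to compound 4 (within the scatter); each core supplies only one pair, which does not show why the two steps differ or whether either would hold for other chains.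

Still open, as far as these compounds go, is how longer chains on the sulfur, such as propylsulfanyl or butylsulfanyl, would read, and whether the sulfur-linked compounds follow any trend with chain length at all. Also open, from the compounds shown here alone, is what an amine nitrogen would give in place of the oxygen or sulfur on the carbonyl carbon.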